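Trimethoxyphenyl series: aryl swap at the five-membered ring

A few compounds are considered here, and "the series" means these few. Any claim that something is new, unique, unknown or untested is made for them only; others in the source may bear on it.

Measured so far:
- compound 1, `COc1cc(-c2ccnc3cc(-c4ccc(Cl)cc4)nn23)cc(OC)c1OC`: 2320 nM
- compound 2, `COc1cc(-c2ccnc3c(-c4ccc(C)cc4)cnn23)cc(OC)c1OC`: > 10000 nM
- compound 3, `Cc1ccc(-c2cc3nccc(-c4ccc(F)cc4)n3n2)cc1`: > 10000 nM

Going by the values given here, in a functional assay on MCF7 cells (Homo sapiens) for inhibition, read by CCK-8 assay, with a stated time of 48 h (on this read-out lower numbers stand for stronger inhibition and higher numbers for weaker inhibition), compound 1 gives 2320 nM and is the only compound of the three to return a number. For compound 2 the result is a limit of the assay, > 10000 nM. For compound 3 the result is likewise a limit, > 10000 nM. Among the compounds with values here, two of the three values therefore sit at the limit of > 10000 nM in this assay, at which 2 of the 3 values shown sit, so no measured step between two numbers exists in this assay and the scatter around compound 1 cannot be judged from its neighbours.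

The next compound, compound 4, `COc1cc(-c2ccnc3cc(-c4ccc5c(ccn5C)c4)nn23)cc(OC)c1OC`, keeps the shared core and the trimethoxyphenyl of compound 1 and changes one group: 1-methyl-1H-indol-5-yl in place of 4-chlorophenyl on an aromatic carbon.

Within the data shown here, with no measured step to lean on, the expectation for this assay is a step of moderate size and downward in the value, i.e. towards stronger inhibition, with the direction uncertain enough that a move within the scatter is also plausible. Compound 4 is thus estimated at 1200 nM, within a range of 300 nM to 6000 nM. Taken as a step, the estimate from compound 1 to compound 4 is a 1.9-fold lower number from compound 1 to compound 4 (0.29 log units; within the scatter), which is expected rather than known.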

Compound 4, half-maximal inhibitory concentration: 3 nM
Compound 4: the middle estimate sits 400-fold (2.60 log units) above what was measured; the whole stated range lies above it.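

In this assay, the aryl group on the aromatic carbon of the five-membered ring proves to be a decisive point in the series: with the shared core and the trimethoxyphenyl unchanged, 1-methyl-1H-indol-5-yl in place of 4-chlorophenyl gives a 770-fold lower number from compound 1 to compound 4 (2.89 log units; beyond the scatter). Going by these compounds alone, this is the first measured step, and it shows that activity at this position is highly sensitive to the aryl group, which the single number for compound 1 could not show. With compound 4 at 3 nM, the series now has a second number. The other values remain limits: the limit of > 10000 nM in this assay, at which 2 of the 4 values shown sit.

Within the data shown here, the single swap does not separate the contributions of the added five-membered ring, its ring nitrogen and the methyl group of the 1-methyl-1H-indol-5-yl, so it remains open which of these carries the step. Also open, going by these compounds, is whether an amine or a carboxylic acid on the aryl group would keep this level of inhibition, and whether the step holds in cell lines other than MCF7.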